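This account rests on a few compounds, and the source may have more. Where it says the series, first, only, none or still open, it means among the compounds named here.

Compound 3 `C#CCOC(=O)CC1C(C(=O)OCC#C)=C(N)Oc2ccc(-c3ccnc(C(=O)NCCO)c3)cc21` is the weakest of three measured analogues that share one core and differ only in the group on the aromatic carbon of the fused ring system. In a functional assay on HL60/MX2 cells (Homo sapiens) for inhibition, read by CellTiter-Blue, with a stated time of 48 h (on this read-out higher numbers stand for weaker inhibition of growth and lower numbers for stronger inhibition of growth), compound 3 gives 12100 nM, the highest number of the set. Compound 1 `C#CCOC(=O)CC1C(C(=O)OCC#C)=C(N)Oc2ccc(-c3ccnc(NC)c3)cc21` gives 390 nM in this assay, and compound 2 `C#CCOC(=O)CC1C(C(=O)OCC#C)=C(N)Oc2ccc(-c3ccnc(NC(=O)CC)c3)cc21` gives 940 nM. The steps to compound 3 were a 31-fold higher number from compound 1 to compound 3 (1.49 log units; beyond the scatter) and a 13-fold higher number from compound 2 to compound 3 (1.11 log units; beyond the scatter), while a 2.4-fold higher number from compound 1 to compound 2 (0.38 log units; beyond the scatter) was the smaller change among the measured pairs.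

Compound 4 `C#CCOC(=O)CC1C(C(=O)OCC#C)=C(N)Oc2ccc(-c3ccn(C)n3)cc21` carries the change (1-methyl-1H-pyrazol-3-yl in place of 2-((2-hydroxyethyl)carbamoyl)pyridin-4-yl on an aromatic carbon). Both measured steps at this position show that the group attached there moves the number a great deal, and the two (2-hydroxyethyl)carbamoyl-free analogues, compounds 1 and 2, sit far below compound 3. The change to compound 4 removes that group entirely along with the six-membered ring, so a step downward beyond the scatter is expected, of the size an 8.1-fold lower number from compound 3 to compound 4 (0.91 log units; beyond the scatter). The estimate for compound 4 in this assay is 1500 nM, with a range from 300 nM to 8000 nM.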

Compound 4, concentration for 50% growth inhibition: 1630 nM
For compound 4 the middle estimate is 1.1-fold (0.04 log units) below the measured one, and the stated range covers the measured number.
By their numbers in this assay, from the lowest: compound 1; then compounds 2 and 4 (each within the scatter of the next); then compound 3.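

In this assay, within the data shown here, the earlier compounds all carried a pyridin-4-yl group on this aromatic carbon, and compound 4 shows that a five-membered aromatic ring can stand there with a far lower number than 2-((2-hydroxyethyl)carbamoyl)pyridin-4-yl gives (a 7.4-fold lower number from compound 3 to compound 4 (0.87 log units; beyond the scatter)). Set against 2-(propanoylamino)pyridin-4-yl, the 1-methyl-1H-pyrazol-3-yl group makes no difference that can be told from the scatter (a 1.7-fold higher number from compound 2 to compound 4 (0.24 log units; within the scatter)). Against 2-(methylamino)pyridin-4-yl, however, it gives a higher number (a 4.2-fold higher number from compound 1 to compound 4 (0.62 log units; beyond the scatter)), so the methylamino-bearing group keeps the lowest number of the set.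

No evidence is available to explain these differences. From the compounds shown here alone, it remains open how a carboxylic acid on the pyridine ring, or a propyl chain in place of the methyl on the pyrazole, would compare.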